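A Dichlorophenyl Swap in a Narrow Series

A few compounds are considered here, and "the series" means these few. Any claim that something is new, unique, unknown or untested is made for them only; others in the source may bear on it.

In a functional assay on HT-1080 cells (Homo sapiens) for cytotoxicity, read by MTT assay, with a stated time of 72 h (on this read-out higher numbers stand for weaker inhibition and lower numbers for stronger inhibition), three related compounds have been measured. Compound 1 (`COc1cccc(/C=C2\CCC/C(=C\c3ccccc3Cl)C2=O)c1OC`) gives 11700 nM, compound 2 (`COc1cccc(/C=C2\CCC/C(=C\c3ccc(Br)cc3)C2=O)c1OC`) gives 13700 nM, and compound 3 (`COc1ccc(/C=C2\CCC/C(=C\c3cccc(OC)c3OC)C2=O)cc1`) gives 16300 nM. Compound 3 thus stands within the scatter of both others, and the numbers set no order among the three.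

The next compound is compound 4 (`COc1cccc(/C=C2\CCC/C(=C\c3cc(Cl)cc(Cl)c3)C2=O)c1OC`), in which 3,5-dichlorophenyl replaces 4-methoxyphenyl on a double-bonded chain carbon bound to a double-bonded ring carbon: 3,5-dichlorophenyl in place of 4-methoxyphenyl on a double-bonded chain carbon bound to a double-bonded ring carbon.

Among the compounds with values here, three measured steps bear on this change. Placing 4-methoxyphenyl where 2-chlorophenyl stood gave a 1.4-fold higher number from compound 1 to compound 3 (0.14 log units; within the scatter), and methoxy in place of bromo gave a 1.2-fold higher number from compound 2 to compound 3 (0.08 log units; within the scatter). Exchanging 2-chlorophenyl for 4-bromophenyl gave a 1.2-fold higher number from compound 1 to compound 2 (0.07 log units; within the scatter). Within the data shown here, none of the measured compounds carries 3,5-dichlorophenyl, so this group itself remains untested. Even so, all three steps stayed within the scatter, and no step beyond it is expected in this assay.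

The expected step is a 1.3-fold lower number from compound 3 to compound 4 (0.10 log units; within the scatter), which would leave compound 4 close to the two halogen-bearing compounds. For compound 4 the estimated value is 13000 nM, with an expected range from 6500 nM to 26000 nM.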

Compound 4, half-maximal inhibitory concentration: 6100 nM
For compound 4 the middle estimate is 2.1-fold (0.33 log units) above the measured one; the whole stated range lies above it.
By their numbers in this assay, from the lowest: compounds 4, 1, 2 and 3 (each within the scatter of the next, the first and the last beyond it).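

Within the data shown here, at this position, on a double-bonded chain carbon bound to a double-bonded ring carbon, 3,5-dichlorophenyl gives the first steps in this assay that pass beyond the scatter, though both are modest: a 2.7-fold lower number from compound 3 to compound 4 (0.43 log units; beyond the scatter) when it replaces 4-methoxyphenyl, and a 2.2-fold lower number from compound 2 to compound 4 (0.35 log units; beyond the scatter) when it replaces 4-bromophenyl. The position therefore does respond to the aromatic group it carries, and the step from 4-methoxyphenyl comes with no difference in heavy-atom count between the group that leaves and the one that enters, but the response has limits, since replacing 2-chlorophenyl gives only a 1.9-fold lower number from compound 1 to compound 4 (0.28 log units; within the scatter). Nothing available accounts for these steps.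

Whether the two chlorines of 3,5-dichlorophenyl matter as chlorines remains open, as the compounds shown do not tell how two methoxy or two trifluoromethyl groups at the same places would read in this assay. Also open, going by these compounds, is whether an amine or a carboxylic acid on this aromatic ring would keep, extend or reverse the modest steps seen here.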